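Swapping a naphthalene for a tert-butylphenyl ester arm

This account rests on a few compounds, and the source may have more. Where it says the series, first, only, none or still open, it means among the compounds named here.

In a functional assay on MCF7 cells (Homo sapiens) for antiproliferative activity, read by MTT assay, with a stated time of 72 h, tested at 25 uM (on this read-out higher numbers stand for a weaker effect at the one concentration tested and lower numbers for a stronger effect), compound 1, with structure `COC(C(=O)OC(C)Cn1cnc2c1c(=O)n(C)c(=O)n2C)c1cccc2ccccc12`, gives 92.6%. That is the highest number of the three measured compounds, so compound 1 shows the weakest effect at the concentration tested. The nearest is compound 2, `CC(Cn1cnc2c1c(=O)n(C)c(=O)n2C)OCc1cn(CCCn2cnc3c(Br)c(Br)c(Br)c(Br)c32)nn1`, which in this assay gives 74.5%, a gap beyond the scatter. The furthest is compound 3, `CC(Cn1cnc2c1c(=O)n(C)c(=O)n2C)OCc1cn(CCCn2nc3c(Br)c(Br)c(Br)c(Br)c3n2)nn1`, which in this assay gives 58.3%, also beyond the scatter from compound 1.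

Compound 4, `COC(C(=O)OC(C)Cn1cnc2c1c(=O)n(C)c(=O)n2C)c1ccc(C(C)(C)C)cc1`, has not yet been measured. It differs from compound 1 in one place: 4-(tert-butyl)phenyl in place of naphthalen-1-yl on a saturated chain carbon bound to a carbonyl carbon and an oxygen on a saturated carbon. Among the compounds with values here, no step between two measured compounds matches this change, and compounds 2 and 3 carry a different arm altogether, so they give no guide for it. With nothing to set it apart from compound 1, the step from compound 1 to compound 4 is expected to be small, within the scatter, in either direction: a number 3.6 percentage points lower from compound 1 to compound 4 (within the scatter). In this assay compound 4 is therefore estimated at 89%, with a range from 72% to 100%.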

Compound 4, a percentage reported as activity, at one concentration (the size of the read-out at that concentration, not a potency): 82.2%
Compound 4: the middle estimate sits 6.8 percentage points above what was measured; measured number inside the range.
By their numbers in this assay, from the lowest: compound 3; then compounds 2 and 4 (each within the scatter of the next); then compound 1.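

In this assay, the arm on a saturated chain carbon bound to a carbonyl carbon and an oxygen on a saturated carbon proves able to move the read-out: 4-(tert-butyl)phenyl in place of naphthalen-1-yl gives a number 10.4 percentage points lower from compound 1 to compound 4 (beyond the scatter) and so a modest shift towards a stronger effect. Both groups have the same count of heavy atoms, all carbon, so this step goes with one aromatic ring replacing two, not with a change in heavy-atom count. No measurement shown accounts for the step.

As far as these compounds go, since the second ring is lost and the tert-butyl gained in a single change, the part each plays remains open. Unsubstituted phenyl, 4-methylphenyl or 4-aminophenyl at this place could separate them, and whether a larger step is possible here is also unsettled.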